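Propargyl thioether replacing dichlorobenzyl in the shared core

A few compounds are considered here, and "the series" means these few. Any claim that something is new, unique, unknown or untested is made for them only; others in the source may bear on it.

Three members of the series carry measured numbers in a functional assay on MGC-803 cells (Homo sapiens) for inhibition, read by MTT assay, with a stated time of 72 h; a higher number here means a weaker inhibitor, a lower number a stronger inhibitor. Compound 1 `Cc1cc(Nc2cc(-c3ccccc3)[nH]n2)n2nc(SCc3c(Cl)cccc3Cl)nc2n1` gives 5280 nM in this assay. Compound 2 `Cc1cc(Nc2cc(-c3ccc(F)cc3)[nH]n2)n2nc(SCc3ccc(Br)cc3)nc2n1` gives 2210 nM in this assay, and compound 3 `Cc1cc(Nc2ccn(Cc3ccc(C(F)(F)F)cc3)n2)n2nc(SCc3ccc(Br)cc3)nc2n1` gives 2590 nM in this assay. Among these three, compound 1 shows the highest number; its gap to compound 3 is the nearest one and its gap to compound 2 the widest, and both gaps lie beyond the scatter of repeated measurements. No pairs of these compounds differ in a single place, so no measured single step is available.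

Compound 4 `C#CCSc1nc2nc(C)cc(Nc3cc(-c4ccccc4)[nH]n3)n2n1` is the next candidate. It differs from compound 1 in one place: ethynyl in place of 2,6-dichlorophenyl on a saturated chain carbon bound to a sulfur. The core and the remaining substituents of compound 1 are kept.

Without a measured step, the step from compound 1 is expected to be modest and toward a higher number, as a 1.7-fold higher number from compound 1 to compound 4 (0.23 log units; within the scatter) expresses. For compound 4 the estimate in this assay is 9000 nM, with a range from 3000 nM to 30000 nM.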

Compound 4, half-maximal inhibitory concentration: 13400 nM
Compound 4: middle estimate off by 1.5-fold (0.17 log units), on the low side, and the stated range covers the measured number.
By their numbers in this assay, from the lowest: compounds 2 and 3 (each within the scatter of the next); then compound 1; then compound 4.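

In this assay, this first single-place step in the series gives a 2.5-fold higher number from compound 1 to compound 4 (0.40 log units; beyond the scatter), beyond the scatter, which shows that the group on a saturated chain carbon bound to a sulfur affects the number. With ethynyl in place of 2,6-dichlorophenyl, the ring and the chlorines leave together, and the propargyl thioether stays on the higher side of the 2,6-dichlorobenzyl thioether on the core of compound 1. Nothing measured here accounts for the size or direction of this step.

From the compounds shown here alone, it remains open whether the ring or the chlorines carry the step, and an unsubstituted benzyl or a plain propyl group at this place would bear on that. Also open, going by these compounds, is whether the same change gives a similar step on other amino substituents of the shared core.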